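Extending the fluorinated chain of compound 3

This account rests on a few compounds, and the source may have more. Where it says the series, first, only, none or still open, it means among the compounds named here.

In a functional assay on T47D cells (Homo sapiens) for inhibition, read by sulforhodamine B assay, with a stated time of 48 h (a higher number here means a weaker inhibitor of growth, a lower number a stronger inhibitor of growth), compound 3 `O=C(CCC(F)(F)C(F)(F)C(F)(F)C(F)(F)C(F)(F)C(F)(F)F)NCCCCCCCCCN[C@@H]1[C@H](O)[C@@H](O)[C@@H](O)[C@H]2COC(=O)N21` gives 15000 nM. That value lies within the usual scatter of compound 1 `O=C(CCC(F)(F)C(F)(F)C(F)(F)C(F)(F)C(F)(F)C(F)(F)F)NCCCCCCCCCN[C@@H]1[C@H](O)[C@@H](O)[C@H](O)[C@H]2COC(=O)N21`, which gives 11000 nM. These two form a stereochemical pair: the fact that compounds 1 and 3 differ only in the configuration as drawn. The measured step between them is a 1.4-fold higher number from compound 1 to compound 3 (0.13 log units; within the scatter). Compound 2 `O=C(CCC(F)(F)C(F)(F)C(F)(F)C(F)(F)C(F)(F)C(F)(F)C(F)(F)C(F)(F)F)NCCCCCCCCCN[C@@H]1[C@H](O)[C@@H](O)[C@H](O)[C@H]2COC(=O)N21` gives > 100000 nM, which is a limit of this assay and not a number.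

Compound 4 `O=C(CCC(F)(F)C(F)(F)C(F)(F)C(F)(F)C(F)(F)C(F)(F)C(F)(F)C(F)(F)F)NCCCCCCCCCN[C@@H]1[C@H](O)[C@@H](O)[C@@H](O)[C@H]2COC(=O)N21` is made from compound 3 by one change: 1,1,2,2,2-pentafluoroethyl in place of fluoro on a saturated chain carbon bound to two fluorine atoms and a saturated chain carbon. Put simply, 1,1,2,2,2-pentafluoroethyl stands in place of fluoro on a saturated chain carbon bound to two fluorine atoms and a saturated chain carbon. This same exchange has been measured once, on the other member of the stereochemical pair: an at least 9.0-fold higher number from compound 1 to compound 2 (0.95 log units; beyond the scatter). That single step is the main evidence here, and one pair is a thin basis for a forecast. The pair's close agreement in this assay still suggests that the exchange may act similarly in both configurations. A clear loss of growth inhibition is therefore expected, meaning a higher number, and a result reported only as a limit is quite possible. The expected size of the change is a 6.7-fold higher number from compound 3 to compound 4 (0.82 log units; beyond the scatter). For compound 4 the estimated value is 100000 nM, with an expected range from 30000 nM to 200000 nM.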

Compound 4, concentration for 50% growth inhibition: > 100000 nM
Compound 4 ended at the assay's limit (the forecaster's own chance of this, stated with the estimate: 65%); the middle value lies on the limit itself.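

In this assay, the exchange of fluoro for 1,1,2,2,2-pentafluoroethyl gives an at least 6.6-fold higher number from compound 3 to compound 4 (0.82 log units; beyond the scatter), so the loss of growth inhibition first seen on one configuration now appears on the other as well. Compound 1 and compound 3 differ only at one stereocentre, and the step lies beyond the usual scatter on both, so this change at this position no longer rests on a single pair: the same change on two cores in this assay, an at least 9.0-fold higher number (0.95 log units; beyond the scatter) from compound 1 to compound 2 and an at least 6.6-fold higher number (0.82 log units; beyond the scatter) from compound 3 to compound 4; the limit leaves it open whether they differ. A new comparison between the two configurations of the longer chain does not follow, however, and the step between compound 2 and compound 4 cannot be read because each value is only a limit: the limit of > 100000 nM in this assay, at which 2 of the 4 values shown sit.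

On these data alone, it therefore remains open whether configuration matters at all for the longer fluorinated chain, since neither compound has a true number in this assay. Also open, as far as these compounds go, is how the growth inhibition of compound 1 and compound 3 would compare with that of the same core carrying a shorter fluorinated chain, or a plain octyl chain with no fluorine in it.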